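Removing a Chloro Group: Two Parallel Thiazole Pairs

The source may hold more compounds than are shown below. What is called first, only, known or untested is meant among the compounds shown, and "the series" means these compounds.

Compound 1 `Cc1nc(-c2ccc(Cl)cc2)sc1C(=O)CSc1nc(-c2ccccc2)c(C#N)c(=O)[nH]1`: 41.6%
Compound 2 `Cc1nc(-c2ccccc2)sc1C(=O)CSc1nc(N)c(C#N)c(-c2ccc(Cl)cc2)n1`: 44.3%
Compound 3 `Cc1nc(-c2ccccc2)sc1C(=O)CSc1nc(-c2ccccc2)c(C#N)c(=O)[nH]1`: 77.5%

All three were tested in a functional assay on U-87MG ATCC cells for antiproliferative activity against U-87 MG (Homo sapiens), read by MTT assay, with a stated time of 48 h, tested at 50 uM; a lower number here means a stronger effect, a higher number a weaker effect of the compound at the concentration tested. Compound 1 and compound 3 share one core and differ in a single place, (hydrogen in place of chloro on an aromatic carbon). That change produced a number 35.9 percentage points higher from compound 1 to compound 3 (beyond the scatter), so the compound without the chloro group has a weaker effect. Compound 2 is built on a different core; the difference between the two cores is not broken down here. Its value sits close to that of compound 1.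

Compound 4 `Cc1nc(-c2ccccc2)sc1C(=O)CSc1nc(N)c(C#N)c(-c2ccccc2)n1` has not yet been measured. It stands to compound 2 exactly as compound 3 stands to compound 1: hydrogen in place of chloro on an aromatic carbon, at the same place. Because a number 35.9 percentage points higher from compound 1 to compound 3 (beyond the scatter) was a large step, a step of similar size is expected here, a number 29.7 percentage points higher from compound 2 to compound 4 (beyond the scatter). Compound 4 is accordingly estimated at 74%, with a plausible range from 58% to 90%.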

Compound 4, a percentage reported as activity, at one concentration (the size of the read-out at that concentration, not a potency): 26.3%
Beside the measured number, compound 4's estimate is 47.7 percentage points above it; measured number outside the range, below it.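

In this assay, going from 4-chlorophenyl to phenyl gave a number 18 percentage points lower from compound 2 to compound 4 (beyond the scatter), so in this pair the compound without the chloro group has the stronger effect. The change therefore does not carry over from one core to the other, since the two steps run in opposite directions: the same change on two cores in this assay, a number 35.9 percentage points higher (beyond the scatter) from compound 1 to compound 3 and a number 18 percentage points lower (beyond the scatter) from compound 2 to compound 4, 53.9 percentage points apart, beyond the scatter of two such steps. This shows that the earlier step cannot be transferred to a new core in this series, but it does not show which structural difference reverses the outcome, and two pairs establish no general rule.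

The compounds shown leave open how a fluoro or methoxy group on the same aromatic carbon would behave on each core. They also leave open whether either result would favour hydrogen or chloro on a third core.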